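Chloro for methoxy on the hydrazone aryl ring

The source may report more compounds than this note shows. Statements on the series, on what has been measured and on what is new or still open speak of the compounds shown alone.

Measured so far:
Compound 1, `COc1ccccc1/C=N/Nc1nc2ccccc2nc1Cc1ccccc1`: 790000 nM
Compound 2, `C(=N/Nc1nc2ccccc2nc1Cc1ccccc1)\c1ccccc1`: 320000 nM

In an assay on isolated protein for inhibition of Amine oxidase [flavin-containing] B (Homo sapiens), read by spectrophotometry (on this read-out lower numbers stand for stronger inhibition and higher numbers for weaker inhibition), compound 1 gives 790000 nM, the highest of the two numbers; its nearest neighbour is compound 2, whose number lies a 2.5-fold lower number from compound 1 to compound 2 (0.39 log units; beyond the scatter) away. Compound 3, `Clc1ccccc1/C=N/Nc1nc2ccccc2nc1Cc1ccccc1`, differs from compound 1 by chloro in place of methoxy on an aromatic carbon. Going by the values given here, the one step that bears on this change is the one from compound 1 to compound 2, where removing the methoxy gave a modest 2.5-fold lower number from compound 1 to compound 2 (0.39 log units; beyond the scatter). Compound 3 keeps a substituent at the same place, so it is expected to land near that gap rather than beyond it, most likely a little below compound 1. The step from compound 1 to compound 3 is therefore estimated at a 2.0-fold lower number from compound 1 to compound 3 (0.30 log units; within the scatter), in the direction of stronger inhibition. Compound 3 is expected to give 400000 nM, within a range from 150000 nM to 1000000 nM.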

Compound 3, half-maximal inhibitory concentration: 87000 nM
Compound 3: the middle estimate sits 4.6-fold (0.66 log units) above what was measured; the measured number lies below the stated range.
By their numbers in this assay, from the lowest: compound 3; then compound 2; then compound 1.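

In this assay the 2-chlorophenyl compound does not fall between the earlier two: the change gives a 9.1-fold lower number from compound 1 to compound 3 (0.96 log units; beyond the scatter) and also a 3.7-fold lower number from compound 2 to compound 3 (0.57 log units; beyond the scatter) on the same read-out. A substituent on this aromatic carbon, ortho to a large group, is therefore not simply worse than hydrogen, since methoxy gives a higher number than hydrogen and chloro a lower one, so the identity of the group decides the direction of the step. Nothing measured here accounts for the opposite directions of these two groups.

The compounds shown leave open whether this gain is particular to chloro or would also appear with fluoro, bromo or methyl at this place, and how an amine or a carboxylic acid would fare there. They also leave open whether chloro would give a similar step on the other carbons of this ring.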